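Amide-Nitrogen Aryl Swap on a Furan Carboxamide Phenol

The source may hold more compounds than are shown below. What is called first, only, known or untested is meant among the compounds shown, and "the series" means these compounds.

Measured compounds:
compound 1, `Cc1ccccc1N(C)C(=O)c1ccc(-c2ccc(O)cc2)o1`, 21 nM
compound 2, `Cc1ccccc1N(C)C(=O)c1ccc(-c2ccccc2O)o1`, 1900 nM
compound 3, `Cc1ccccc1N(C)C(=O)c1ccc(-c2ccc(O)c(Cl)c2)o1`, 52 nM

In an assay on T47D cells for inhibition of 17-beta-hydroxysteroid dehydrogenase type 1 (Homo sapiens), read by HPLC, with a stated time of 24 h (a lower number here means a stronger inhibitor, a higher number a weaker inhibitor), compound 1 gives the lowest of the three numbers. Its nearest neighbour is compound 3, reached by a 2.5-fold higher number from compound 1 to compound 3 (0.39 log units; beyond the scatter). The furthest is compound 2, reached by a 90-fold higher number from compound 1 to compound 2 (1.96 log units; beyond the scatter). Between the other two, a 37-fold lower number from compound 2 to compound 3 (1.56 log units; beyond the scatter) shows the same pattern.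

Compound 4, `Cc1cccnc1N(C)C(=O)c1ccc(-c2ccc(O)cc2)o1`, differs from compound 1 at a different place: 3-methylpyridin-2-yl in place of 2-methylphenyl on an amide-type nitrogen. For the measured compounds named here, none of the measured steps touches the group on the amide-type nitrogen; all of them alter the hydroxyphenyl ring, where the two large steps and one modest step were seen. The data therefore give no direct guide, and the expected step in this assay is modest, without a firm direction, with a slight lean towards a higher number.

Compound 4 is estimated at 35 nM, within 10 nM to 120 nM, corresponding to an expected step of a 1.7-fold higher number from compound 1 to compound 4 (0.22 log units; within the scatter).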

Compound 4, half-maximal inhibitory concentration: 1100 nM
Compound 4: the middle estimate sits 31-fold (1.50 log units) below what was measured; measured number outside the range, above it.
By their numbers in this assay, from the lowest: compound 1; then compound 3; then compounds 4 and 2 (each within the scatter of the next).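

For the compounds shown here, the amide-type nitrogen, which no earlier step touched, proves to be a sensitive place: in this assay, 3-methylpyridin-2-yl in place of 2-methylphenyl gives a 52-fold higher number from compound 1 to compound 4 (1.72 log units; beyond the scatter). This step is large, as is a 90-fold higher number from compound 1 to compound 2 (1.96 log units; beyond the scatter) on the hydroxyphenyl ring, so the activity of compound 1 depends on the group on this nitrogen as well as on that ring. The two groups have the same count of heavy atoms and differ by one ring nitrogen in place of carbon, with one hydrogen-bond acceptor gained, and nothing available here accounts for the loss.

On these data alone, it remains open whether other groups on the amide-type nitrogen, such as a plain phenyl or a thienyl, would keep the number of compound 1. Also open, as far as these compounds go, is whether the chloro group of compound 3 would change the number of compound 4.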